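Swapping the charged ring of compound 3 for a urea

The source may hold more compounds than are shown below. What is called first, only, known or untested is meant among the compounds shown, and "the series" means these compounds.

Compound 1, `N#Cc1ccc(C(=O)Nc2ccc3nc(NC(=O)C4CCCCC4)sc3c2)cc1`: 3.3 ug/mL
Compound 2, `O=C(Nc1ccc2nc(NC(=O)C3CCCCC3)sc2c1)c1ccc(Br)cc1`: a limit, > 4 ug/mL
Compound 3, `Cc1[nH][n+](C)c(C)c1C(=O)Nc1ccc2nc(NC(=O)C3CCCCC3)sc2c1`: 0.012 ug/mL

All three compounds share one core carrying a cyclohexane carboxamide, and they differ only in the group attached to the second carbonyl carbon. In a functional assay on WI-38 VA13 cells (Homo sapiens) for cytotoxicity (a lower number here means that less compound is needed, a higher number that more compound is needed for the effect), compound 1 gives 3.3 ug/mL. For compound 2 the assay reports only a limit, > 4 ug/mL, one of the values sitting at the limit of > 4 ug/mL in this assay, at which 1 of the 3 values shown sits. Compound 3 gives 0.012 ug/mL, the lowest of the two numbers shown; the step of a 280-fold lower number from compound 1 to compound 3 (2.44 log units; beyond the scatter) is large, and so is an at least 330-fold lower number from compound 2 to compound 3 (2.52 log units; beyond the scatter). Between the two six-membered carbon rings themselves the step of an at least 1.2-fold higher number from compound 1 to compound 2 (0.08 log units; that floor lies within the scatter) tells little, as its floor lies within the scatter.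

Compound 4, `Cc1cccc(C)c1NC(=O)Nc1ccc2nc(NC(=O)C3CCCCC3)sc2c1`, has not yet been measured. It differs from compound 3 by a group of 9 heavy atoms (8 carbon, 1 nitrogen; one six-membered aromatic ring of carbon only) in place of a group of 8 heavy atoms (6 carbon, 2 nitrogen; one five-membered aromatic ring with 2 hetero atoms), on a carbonyl carbon. This runs the two large measured steps in reverse: a six-membered carbon ring returns in place of the five-membered ring, now joined through an amino linker. A large rise in the number is therefore expected, a 250-fold higher number from compound 3 to compound 4 (2.40 log units; beyond the scatter), bringing compound 4 back near compound 1, whose value is 3.3 ug/mL. Compound 4 is expected to give about 3 ug/mL, in a range from 0.6 ug/mL to 8 ug/mL, with a fair chance that only a limit is reported.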

Compound 4, half-maximal effective concentration: 0.56 ug/mL
Beside the measured number, compound 4's estimate is 5.4-fold (0.73 log units) above it; the whole stated range lies above it.
By their numbers in this assay, from the lowest: compound 3; then compound 4; then compound 1. At a limit, above all of these: compound 2.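

Changing 4-cyanophenyl to (2,6-dimethylphenyl)amino on the carbonyl carbon gives a 5.9-fold lower number from compound 1 to compound 4 (0.77 log units; beyond the scatter) in this assay, so a six-membered carbon ring at this position does not have to leave the number high. Against 4-bromophenyl the same change gives an at least 7.1-fold lower number from compound 2 to compound 4 (0.85 log units; beyond the scatter), and this step is only a floor, as compound 2 stands as a limit: the limit of > 4 ug/mL in this assay, at which 1 of the 4 values shown sits. The net charge of compound 3 is not essential for a number below those of compound 1 and compound 2, yet the uncharged group does not match it, with a 47-fold higher number from compound 3 to compound 4 (1.67 log units; beyond the scatter).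

Compound 4 alters the ring, the net charge and the link to the carbonyl carbon in one step, so the compounds shown cannot say which of these parts accounts for any of the steps. On these data alone, it also stays open whether a plain phenylamino group, without the two methyl groups, would give a number nearer to compound 4 or to compound 1, and what a 4-cyanophenylamino group would give at this place.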